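Metabolic stability across a set of aminopyridine-type headgroups

A few compounds are considered here, and "the series" means these few. Any claim that something is new, unique, unknown or untested is made for them only; others in the source may bear on it.

Compound 3 `FC(F)(F)c1cccc(-c2nc3cnc(Nc4cnccn4)cc3[nH]2)c1` stands second highest of the three measured in an ADME assay on microsomes from liver (Homo sapiens) for metabolic stability, read by LC-MS, with a stated time of 30 min, tested at 0.1 uM (on this read-out lower numbers stand for a less stable compound and higher numbers for a more stable compound), where it gives 43%. Compound 2 `FC(F)(F)c1cccc(-c2nc3cnc(Nc4ccncn4)cc3[nH]2)c1` gives 90% in this assay, and compound 1 `COc1ccc(Nc2cc3[nH]c(-c4cccc(C(F)(F)F)c4)nc3cn2)nc1` gives 26%. Exchanging the headgroup has moved the numbers strongly: a number 64 percentage points higher from compound 1 to compound 2 (beyond the scatter), a number 47 percentage points lower from compound 2 to compound 3 (beyond the scatter), and a number 17 percentage points higher from compound 1 to compound 3 (beyond the scatter). Compound 4 `N#Cc1ccc(Nc2cc3[nH]c(-c4cccc(C(F)(F)F)c4)nc3cn2)nc1` is the next in line, differing from compound 3 by 5-cyanopyridin-2-yl in place of pyrazin-2-yl on a nitrogen on an aromatic ring. Among the measured compounds shown here, no measured step involves the 5-cyanopyridin-2-yl group, so the closest guide is the step between the two pyridin-2-yl and pyrazin-2-yl bearers, a number 17 percentage points higher from compound 1 to compound 3 (beyond the scatter), which was modest, while the steps to and from compound 2 show that this position can swing the read-out widely. Compound 4 is therefore expected to land near compound 3, with an estimated step of a number 7 percentage points higher from compound 3 to compound 4 (within the scatter), which would be within the scatter. Compound 4 is estimated at 50%, with a range from 25% to 80%.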

Compound 4, percent of the compound remaining: 39%
Compound 4: the middle estimate sits 11 percentage points above what was measured, within the range that was stated.
By their numbers in this assay, from the lowest: compound 1; then compounds 4 and 3 (each within the scatter of the next); then compound 2.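

In this assay the 5-cyanopyridin-2-yl group gives the first step among these headgroups that stays within the scatter, a number 4 percentage points lower from compound 3 to compound 4 (within the scatter), so 5-cyanopyridin-2-yl and pyrazin-2-yl on this nitrogen cannot be told apart. Cyano in place of methoxy on an aromatic carbon gives a number 13 percentage points higher from compound 1 to compound 4 (beyond the scatter), which shows that a change on the outer part of the pyridin-2-yl group alone can shift the read-out beyond the scatter. With a number 51 percentage points lower from compound 2 to compound 4 (beyond the scatter) as well, pyrimidin-4-yl now stands clear of all three other headgroups.

Going by these compounds, what an amine or a carboxylic acid would give in place of cyano on that aromatic carbon remains open. So does the effect of a methoxy or cyano group carried on the pyrimidin-4-yl ring. Nothing presented here offers an explanation for these numbers.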